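The source may hold more compounds than are shown below. What is called first, only, known or untested is meant among the compounds shown, and "the series" means these compounds.

Measured compounds in an assay on isolated protein for inhibition of Rho-associated protein kinase 1 (Homo sapiens), read by scintillation counting, radiometric assay and 33P incorporation, with a stated time of 40 min, in the presence of a further agent that is not named here; on this read-out higher numbers stand for weaker inhibition and lower numbers for stronger inhibition:
- compound 1, `CC(=O)c1ccc(OCC(=O)Nc2cccc(NC(=O)c3ccc(N(C)C)cc3)c2)cc1F`: 445 nM
- compound 2, `CN(C)c1ccc(C(=O)Nc2cccc(NC(=O)COc3ccc4c(c3)OCCO4)c2)cc1`: > 10000 nM
- compound 3, `CC(=O)Nc1cccc(NC(=O)COc2ccc3c(=O)ccoc3c2)c1`: 2500 nM

The value of compound 2 is a limit of this assay and not a number (the limit of > 10000 nM in this assay, at which 1 of the 3 values shown sits). Among the two numbers, compound 3 stands highest; compound 1 sits nearest, with a lower number, and the gap is beyond the scatter. Going by the values given here, the one step measured in a single place is an at least 22-fold higher number from compound 1 to compound 2 (1.35 log units; beyond the scatter), which concerns the aryl group on the ether oxygen and says nothing about the amide side.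

Compound 4, `O=C(COc1ccc2c(=O)ccoc2c1)Nc1cccc(NC(=O)c2ccc([N+](=O)[O-])cc2)c1`, is the next compound. Its difference from compound 3 is 4-nitrophenyl in place of methyl on a carbonyl carbon. Among the compounds with values here, no measured step covers this change. Compound 1 carries an aryl carbonyl at the same amide and gives 445 nM, but it differs from compound 3 in the ether aryl too, so its two values only hint that an aryl group here is tolerated.

For compound 4 the expectation is a modest drop, a 2.8-fold lower number from compound 3 to compound 4 (0.44 log units; beyond the scatter), with wide uncertainty; the estimate is 900 nM, within 200 nM to 4000 nM.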

Compound 4, half-maximal inhibitory concentration: 67 nM
Estimate against measurement, compound 4: 13-fold (1.13 log units) above; measured number outside the range, below it.
By their numbers in this assay, from the lowest: compound 4; then compound 1; then compound 3. At a limit, above all of these: compound 2.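

On the carbonyl carbon whose other neighbour is the amide-type nitrogen, 4-nitrophenyl in place of methyl can now be read as a single change on an otherwise unchanged structure: in this assay it gives a 37-fold lower number from compound 3 to compound 4 (1.57 log units; beyond the scatter). The earlier values only hinted that an aryl group is tolerated here; this step shows that, with the ether side held fixed, the change from acetyl to (4-nitrophenyl)carbonyl carries a large gain in inhibition. Nothing measured here accounts for the size of this step.

Going by these compounds, whether the gain comes with the aryl ring alone or needs the nitro group stays open, and a plain phenyl, or a phenyl carrying an amine or a carboxylic acid in its place, would separate the two. Also open, on these data alone, is whether the step carries over to other aryl groups on the ether oxygen.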